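This account rests on a few compounds, and the source may have more. Where it says the series, first, only, none or still open, it means among the compounds named here.

Measured compounds:
compound 1, `COc1ccc(/C=C/C(=O)c2ccc(NC(=O)CBr)cc2)cc1` — 41%
compound 2, `COc1ccc(/C=C/C(=O)c2ccc(NC(=O)C(C)Br)cc2)cc1` — 38%

Of the compounds shown here, two have been measured in a functional assay on the whole organism (strain albino) for inhibition, with Rattus norvegicus as the target, read by paw edema, with stated times of 30 min and 4 h, at a dose of 100 mg/kg by the oral route; on this read-out higher numbers stand for more inhibition at the one dose given (going by the name of the read-out) and lower numbers for less inhibition. Compound 1 gives 41%, and compound 2 gives 38%. On these two numbers compound 1 stands highest, but its nearest neighbour, compound 2, lies only a number 3 percentage points lower from compound 1 to compound 2 (within the scatter), which is within the scatter, so the two are not told apart. Compound 3, `COc1ccc(/C=C/C(=O)c2ccc(NC(=O)COc3ccc(C(C)=O)cc3)cc2)cc1`, has not yet been measured. It differs from compound 1 in one place: 4-acetylphenoxy in place of bromo on a saturated chain carbon bound to a carbonyl carbon. Within the data shown here, the only measured step, from methyl in place of hydrogen on a saturated chain carbon bound to a bromine atom and a carbonyl carbon, concerns another change and did not move the number beyond the scatter. Among the measured compounds shown here, no measured step bears on the exchange of bromo for 4-acetylphenoxy, so nothing here points in either direction. Compound 3 is therefore expected to sit near compound 1, with the step of no change at the digits printed from compound 1 to compound 3 (within the scatter) estimated to lie within the scatter. The estimate for compound 3 is 41%, in a range from 26% to 56%.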

Compound 3, a percentage reported as inhibition, in the whole organism at one dose (the size of the read-out at that dose, not a potency): 33%
For compound 3 the middle estimate is 8 percentage points above the measured one; the measured number falls inside the stated range.
By their numbers in this assay, from the lowest: compounds 3, 2 and 1 (each within the scatter of the next).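

In this assay, placing 4-acetylphenoxy in place of bromo on a saturated chain carbon bound to a carbonyl carbon gives a number 8 percentage points lower from compound 1 to compound 3 (within the scatter). This position therefore accepts a group containing a six-membered aromatic ring in place of a single bromine atom without compound 3 being told apart from compound 1, so the bromine atom is not shown to be needed for the inhibition seen at this dose. Nothing measured on these compounds bears on why the exchange leaves the two numbers within the scatter.

The compounds shown leave open whether an amine, a carboxylic acid or a plain phenoxy group on the same carbon would move the number beyond the scatter. Among these compounds, they also leave open whether this position influences the read-out at all, since every number so far lies within the scatter of the next.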